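Branched nitrogen substituents on a corticotropin-releasing factor antagonist core

The source may report more compounds than this note shows. Statements on the series, on what has been measured and on what is new or still open speak of the compounds shown alone.

Of the compounds shown here, three sharing one core have been measured in a functional assay for antagonist activity at corticotropin-releasing factor receptor 1 (Rattus norvegicus); a lower number here means a stronger inhibitor, a higher number a weaker inhibitor. Compound 1 `CC[C@H](C1CC1)n1c(=O)c(C)nc2c(-c3ccc(Cl)cc3Cl)ccnc21` gives 8.2 nM, compound 2 `CCCC(C)n1c(=O)c(C)nc2c(-c3ccc(Cl)cc3Cl)ccnc21` gives 62 nM, and compound 3 `Cc1nc2c(-c3ccc(Cl)cc3Cl)ccnc2n(CC(C)C)c1=O` gives 3500 nM, the highest number of the three. The steps from compound 1 and compound 2 to compound 3, a 430-fold higher number from compound 1 to compound 3 (2.63 log units; beyond the scatter) and a 56-fold higher number from compound 2 to compound 3 (1.75 log units; beyond the scatter), were both large. Compound 4 `CC[C@H](COC)n1c(=O)c(C)nc2c(-c3ccc(Cl)cc3Cl)ccnc21` differs from compound 3 in one place: 1-(methoxymethyl)propyl in place of isobutyl on an aromatic nitrogen. The entering group, like 1-cyclopropylpropyl in compound 1 and 1-methylbutyl in compound 2, attaches to the nitrogen through its first carbon with two chains; this is expected to move the number back toward those of compound 1 and compound 2, a large fall, a 120-fold lower number from compound 3 to compound 4 (2.07 log units; beyond the scatter). Compound 4 is therefore estimated at 30 nM, within 8 nM to 120 nM.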

Compound 4, half-maximal inhibitory concentration: 4 nM
Compound 4: middle estimate off by 7.5-fold (0.88 log units), on the high side; the whole stated range lies above it.
By their numbers in this assay, from the lowest: compound 4; then compound 1; then compound 2; then compound 3.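

In this assay, 1-(methoxymethyl)propyl on the aromatic nitrogen in place of isobutyl gives an 880-fold lower number from compound 3 to compound 4 (2.94 log units; beyond the scatter), so a branched group carrying an oxygen is tolerated at this position. Against 1-methylbutyl, the same group gives a 16-fold lower number from compound 2 to compound 4 (1.19 log units; beyond the scatter), while methoxymethyl in place of cyclopropyl gives a 2.1-fold lower number from compound 1 to compound 4 (0.31 log units; beyond the scatter), so the cyclopropyl ring is not required for a low number here. Nothing available accounts for these steps. From the compounds shown here alone, the mirror-image form of the 1-(methoxymethyl)propyl group remains open, as do ethoxymethyl and an amine in place of methoxymethyl.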